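This account rests on a few compounds, and the source may have more. Where it says the series, first, only, none or still open, it means among the compounds named here.

Working notes on the series as read in an ADME assay on FSCLL cells (Homo sapiens) for cytotoxicity, read by MTT assay, with a stated time of 24 h (a lower number here means that less compound is tolerated, a higher number that more compound is tolerated), so far. Compound 1 (`CC(C)C[C@H](NC(=O)[C@@H](N)CO)B(O)O`) gives 1700 nM and compound 2 (`CC(C)C[C@H](NC(=O)[C@@H](N)[C@@H](C)O)B(O)O`) gives 2500 nM in this read-out. Compound 3 (`CC(C)C[C@H](NC(=O)[C@H](CO)NC(=O)c1cnccn1)B(O)O`) gives 210 nM here, the lowest of the three numbers, and its distance to each of the other two lies beyond the scatter.

Next in line is compound 4 (`CC(C)C[C@H](NC(=O)[C@@H](NC(=O)c1cnccn1)[C@@H](C)O)B(O)O`), which has not yet been measured. It carries 1-hydroxyethyl where compound 3 carries hydroxymethyl (methyl in place of hydrogen on a saturated chain carbon bound to an oxygen on a saturated carbon and a saturated chain carbon), which is methyl in place of hydrogen on a saturated chain carbon bound to an oxygen on a saturated carbon and a saturated chain carbon.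

Among the measured compounds shown here, only one measured step bears on this change. It is the same replacement in the simpler pair (a 1.5-fold higher number from compound 1 to compound 2 (0.17 log units; within the scatter)), and it stays within the scatter. Whether it carries over to the amide of compound 3 is not shown by any measured pair. No step beyond the scatter is therefore expected in this assay, with at most a small rise in the number. The expected step is a 1.4-fold higher number from compound 3 to compound 4 (0.15 log units; within the scatter) in this read-out. For compound 4 the estimate is 300 nM in this read-out, with an expected range of 120 nM to 700 nM around it.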

Compound 4, half-maximal cytotoxic concentration: 100 nM
The estimate for compound 4 lay 3.0-fold (0.48 log units) above the measured number, and the stated range ends above it.
By their numbers in this assay, from the lowest: compound 4; then compound 3; then compounds 1 and 2 (each within the scatter of the next).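

In this assay, methyl in place of hydrogen on this saturated chain carbon moves the number beyond the scatter once the amine nitrogen carries (pyrazin-2-yl)carbonyl, with a 2.1-fold lower number from compound 3 to compound 4 (0.32 log units; beyond the scatter). The change from hydroxymethyl to 1-hydroxyethyl therefore does not read the same on the two cores, and the simpler pair alone did not reveal this: the same change on two cores in this assay, a 1.5-fold higher number (0.17 log units; within the scatter) from compound 1 to compound 2 and a 2.1-fold lower number (0.32 log units; beyond the scatter) from compound 3 to compound 4, 3.1-fold (0.49 log units) apart, beyond the scatter of two such steps. With 1-hydroxyethyl in place, (pyrazin-2-yl)carbonyl in place of hydrogen on the amine nitrogen is the much larger of the two new steps, with a 25-fold lower number from compound 2 to compound 4 (1.40 log units; beyond the scatter), so in this pair the amine nitrogen weighs far more on the number than the added methyl does.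

The compounds shown leave open whether a longer chain such as 1-hydroxypropyl, or a methoxymethyl, aminomethyl or carboxylic acid group at this carbon, would take the number further down on the core of compound 3 or reverse the step. They also leave open whether the same dependence on the core holds when a benzoyl or another acyl group replaces (pyrazin-2-yl)carbonyl on the amine nitrogen.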